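The compounds below may be only part of what the source reports. "The series", "measured", "known", "first", "only" and "open" are said of these compounds alone.

Compound 1 `CCCCCCOP(=O)(O)OCCSC(=S)N1CCCCC1` and compound 2 `CCCCCCOP(=O)(O)OCCSC(=S)N1CCN(C)CC1` share a core and differ only at the thiocarbonyl carbon. In a functional assay on MCF7 cells (Homo sapiens) for inhibition, read by MTT assay, with stated times of 18 h and 4 h (on this read-out higher numbers stand for weaker inhibition and lower numbers for stronger inhibition), compound 1 gives 62000 nM, and compound 2 gives 58000 nM. Compound 1 therefore stands at the higher of the two numbers, but the step of a 1.1-fold lower number from compound 1 to compound 2 (0.03 log units; within the scatter) does not separate the two compounds beyond the scatter. Compound 3 `CCCCCCCCCCOP(=O)(O)OCCSC(=S)N1CCCCC1` keeps the ring of compound 1 and changes the chain instead: butyl in place of hydrogen on a saturated chain carbon, six bonds along the chain from an oxygen on an unsaturated carbon. Among the measured compounds shown here, neither measured step touches the chain, so no measured step bears on this change, and the only measured step concerns the ring, with a size within the scatter. With nothing in the data to suggest a shift, the expectation for compound 3 is a number close to that of compound 1, with a wide range to reflect the absence of any comparable step; the expected step is a 1.4-fold lower number from compound 1 to compound 3 (0.14 log units; within the scatter). Compound 3 is thus estimated at 45000 nM, between 10000 nM and 150000 nM.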

Compound 3, half-maximal inhibitory concentration: 7240 nM
Compound 3: middle estimate off by 6.2-fold (0.79 log units), on the high side, outside the stated range (below it).
By their numbers in this assay, from the lowest: compound 3; then compounds 2 and 1 (each within the scatter of the next).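

The chain, not the ring, is where the first clear movement appears: in this assay, butyl in place of hydrogen on this saturated chain carbon gives an 8.6-fold lower number from compound 1 to compound 3 (0.93 log units; beyond the scatter), whereas the ring change gave only a 1.1-fold lower number from compound 1 to compound 2 (0.03 log units; within the scatter). This shows that the number responds to this change at this chain position, moving towards stronger inhibition, though the finding rests on a single pair of compounds. Nothing available on these compounds bears on what lies behind this step.

The compounds shown leave open whether a longer chain, such as dodecyl, would lower the number further or reverse the trend. They also leave open whether the same butyl change would give a similar step with the 4-methylpiperazin-1-yl group of compound 2 in place of piperidin-1-yl.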